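The compounds below may be only part of what the source reports. "The series", "measured", "known", "first", "only" and "open" are said of these compounds alone.

Working notes on the series. Compound 1 `CCC(CC)[C@@H]1C(=O)N[C@H](C2Cc3ccccc3C2)C(=O)N1[C@@H](C(=O)N1CCOCC1)c1ccc(C)nc1` and compound 2 `CCC(CC)[C@@H]1C(=O)N[C@H](C2Cc3ccccc3C2)C(=O)N1[C@@H](C(=O)N(C)C)c1ccc(C)nc1` share one core; compound 3 `COc1ccc([C@H](C(=O)N2CCOCC2)N2C(=O)[C@@H](C3Cc4ccccc4C3)NC(=O)[C@H]2CC(C)C)cn1` and compound 4 `COc1ccc([C@H](C(=O)N(C)C)N2C(=O)[C@@H](C3Cc4ccccc4C3)NC(=O)[C@H]2CC(C)C)cn1` share another. How the two cores differ is not broken down here. In an in vivo ADME assay on the whole organism for pharmacokinetics, with Rattus norvegicus as the target, at a dose of 5 mg/kg by the oral route (on this read-out lower numbers stand for lower oral bioavailability and higher numbers for higher oral bioavailability), compound 1 gives 55% and compound 2 gives 36%. The change from compound 1 to compound 2 is dimethylamino in place of morpholin-4-yl on a carbonyl carbon, and it made a number 19 percentage points lower from compound 1 to compound 2 (beyond the scatter). In this assay compound 3 gives 88%, above compound 1 and compound 2. Compound 4 is not yet measured; it differs from compound 3 by dimethylamino in place of morpholin-4-yl on a carbonyl carbon, the same change at the same place. A step of the same order is expected here, a number 19 percentage points lower from compound 3 to compound 4 (beyond the scatter), because the earlier change gave a number 19 percentage points lower from compound 1 to compound 2 (beyond the scatter). Compound 4 is therefore estimated at 69% in this assay, between 50% and 85%.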

Compound 4, oral bioavailability in the Rattus norvegicus assay: 62%
Estimate against measurement, compound 4: 7 percentage points above; measured number inside the range.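

In the Rattus norvegicus assay compound 3 gives 88% and compound 4 gives 62%; dimethylamino in place of morpholin-4-yl on a carbonyl carbon gives a number 26 percentage points lower from compound 3 to compound 4 (beyond the scatter). Set beside the earlier step, the change carries over from one core to the other in direction and in size: the same change on two cores in the Rattus norvegicus assay, a number 19 percentage points lower (beyond the scatter) from compound 1 to compound 2 and a number 26 percentage points lower (beyond the scatter) from compound 3 to compound 4, 7 percentage points apart, within the scatter of two such steps. This rests on two pairs of compounds only, and it shows neither why the number falls nor that the step would hold on a third core. In a physicochemical assay for solubility, read by HPLC (a higher number here means a more soluble compound, a lower number a less soluble compound), compound 3 gives 249 ug/mL and compound 4 gives 216 ug/mL, and the same change gives a 1.2-fold lower number from compound 3 to compound 4 (0.06 log units; within the scatter).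

On these data alone, whether a step of this size follows with another amine on the same carbonyl carbon, such as piperidine or N-methylpiperazine, remains open. Also open, as far as these compounds go, is what a carboxylic acid would give in place of these amides.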